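The compounds below may be only part of what the source reports. "The series", "measured", "known", "first", "only" and "open" are said of these compounds alone.

Measured compounds in a toxicity assay on the whole organism (strain Icem-CET (SPF Caw)) for cytotoxicity, with Mus musculus as the target; a lower number here means that less compound is needed, a higher number that more compound is needed for the effect:
compound 1 `COc1ccc(/C(C)=C(/C)C(=O)NC2CC2)cc1`: 300 mg/kg
compound 2 `C=CCNC(=O)/C(C)=C(/C)c1ccccc1`: 550 mg/kg
compound 3 `C=CCNC(=O)/C(C)=C(/C)c1ccc(OC)cc1`: 280 mg/kg

Among these three numbers compound 1 differs from compound 3 and from compound 2 only by amounts within the scatter, so no order among them can be claimed. Compound 4 `C/C(C(=O)NC1CC1)=C(\C)c1ccc(Cl)cc1` differs from compound 1 in one place: chloro in place of methoxy on an aromatic carbon. Among the compounds with values here, no measured step swaps methoxy for chloro. The two steps that are known, a 1.1-fold lower number from compound 1 to compound 3 (0.03 log units; within the scatter) and a 2.0-fold lower number from compound 2 to compound 3 (0.29 log units; within the scatter), both stayed within the scatter, and the second of them also changed a group on an aromatic carbon. On this basis no step beyond the scatter is expected for compound 4, that is no change at the digits printed from compound 1 to compound 4 (within the scatter). Compound 4 is therefore estimated at 300 mg/kg, with a range from 150 mg/kg to 600 mg/kg.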

Compound 4, dose for half-maximal effect: 170 mg/kg
Beside the measured number, compound 4's estimate is 1.8-fold (0.25 log units) above it; low and high end bracket the measured number.
By their numbers in this assay, from the lowest: compounds 4, 3, 1 and 2 (each within the scatter of the next, the first and the last beyond it).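

In this assay, chloro in place of methoxy on an aromatic carbon para to a large group gives a 1.8-fold lower number from compound 1 to compound 4 (0.25 log units; within the scatter). The position has now taken a second kind of replacement, one that removes a hydrogen-bond acceptor and an oxygen, on a compound with cyclopropyl on the amide-type nitrogen, without a step beyond the scatter. Nothing available bears on the reason for this result. On these data alone, whether an amine or a carboxylic acid at this position would give a larger step stays open. So does whether chloro gives a similar step with allyl in place of cyclopropyl.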